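Compound 3 and a Cinnamoyl Variant

This account rests on a few compounds, and the source may have more. Where it says the series, first, only, none or still open, it means among the compounds named here.

Compound 3, `CCCCCCCCCCCCNC(=O)[C@@H](NC(=O)c1cc2ccccc2o1)[C@@H](C)O`, gives 21300 nM in a functional assay on SW-620 cells (Homo sapiens) for cytotoxicity, read by MTT assay, with a stated time of 48 h (on this read-out higher numbers stand for weaker inhibition and lower numbers for stronger inhibition), the lowest of the three numbers shown. Compound 1, `CCCCCCCCNC(=O)[C@@H](NC(=O)c1cc2ccccc2o1)[C@@H](C)O`, gives 200000 nM, and compound 2, `CCCCCCCCCCCCNC(=O)[C@@H](NC(=O)c1ccccc1)[C@@H](C)O`, gives 200000 nM. The step of a 9.4-fold lower number from compound 2 to compound 3 (0.97 log units; beyond the scatter) replaces phenyl with 1-benzofuran-2-yl; the step of a 9.4-fold lower number from compound 1 to compound 3 (0.97 log units; beyond the scatter) lengthens the chain. Compound 4, `CCCCCCCCCCCCNC(=O)[C@@H](NC(=O)/C=C/c1ccccc1)[C@@H](C)O`, differs from compound 3 in that (2-phenylethenyl in place of 1-benzofuran-2-yl on a carbonyl carbon). The change 2>3 bears on this: a phenyl at that carbonyl carbon gave the higher number. A 2-phenylethenyl group is neither phenyl nor benzofuranyl, so compound 4 is expected to return part of the way toward compound 2, the step of a 3.8-fold higher number from compound 3 to compound 4 (0.57 log units; beyond the scatter) expected to raise the number beyond the scatter. Compound 4 is estimated at 80000 nM, with a range from 25000 nM to 200000 nM.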

Compound 4, half-maximal inhibitory concentration: 200000 nM
Compound 4: the middle estimate sits 2.5-fold (0.40 log units) below what was measured; the measured number falls inside the stated range.
By their numbers in this assay, from the lowest: compound 3; then compounds 1, 2 and 4 (each within the scatter of the next).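

In this assay, the low number at this carbonyl carbon now belongs to 1-benzofuran-2-yl alone among the three groups shown. Putting 2-phenylethenyl in its place gives a 9.4-fold higher number from compound 3 to compound 4 (0.97 log units; beyond the scatter), while setting it in place of phenyl gives no change at the digits printed from compound 2 to compound 4 (within the scatter), so the added double bond outside aromatic rings does not recover the lower number. Nothing measured here accounts for this difference.

Still open, from the compounds shown here alone, is whether an amine or a carboxylic acid on the 2-phenylethenyl group would change the number. Also open, going by these compounds, is whether a longer chain on the amide-type nitrogen would lower the number of compound 3 further.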